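A few compounds are considered here, and "the series" means these few. Any claim that something is new, unique, unknown or untested is made for them only; others in the source may bear on it.

Compound 1, `CN(c1cc2ncc(=O)[nH]c2cc1NC(=S)NC(=O)c1ccccc1)C1CCCCC1`, gives 11100 nM in an ADME assay on Huh-7 cells (Homo sapiens) for cytotoxicity; on this read-out higher numbers stand for weaker inhibition and lower numbers for stronger inhibition. Compound 2, `CN(c1cc2ncc(=O)[nH]c2cc1NC(=S)NC(=O)c1ccc(F)cc1)C1CCCCC1`, carries fluoro in place of hydrogen on an aromatic carbon and gives 11400 nM; the step of a 1.0-fold higher number from compound 1 to compound 2 (0.01 log units; within the scatter). Compound 3, `CN(c1cc2ncc(=O)[nH]c2cc1Nc1nc(-c2ccccc2)cs1)C1CCCCC1`, rests on a core whose difference from the core of compound 1 is not broken down here, and in this assay compound 3 gives 62500 nM. Compound 4, `CN(c1cc2ncc(=O)[nH]c2cc1Nc1nc(-c2ccc(F)cc2)cs1)C1CCCCC1`, is not yet measured; it carries fluoro in place of hydrogen on an aromatic carbon, the same change that was made from compound 1 to compound 2. Since the step from compound 1 to compound 2 was a 1.0-fold higher number from compound 1 to compound 2 (0.01 log units; within the scatter), compound 4 is expected to move from compound 3 by a 1.0-fold lower number from compound 3 to compound 4 (0.00 log units; within the scatter). In this assay compound 4 is therefore estimated at 62000 nM, between 28000 nM and 140000 nM.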

Compound 4, half-maximal inhibitory concentration: 9920 nM
Compound 4: the middle estimate sits 6.3-fold (0.80 log units) above what was measured; the measured number lies below the stated range.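

In this assay, the change from phenyl to 4-fluorophenyl gives a 6.3-fold lower number from compound 3 to compound 4 (0.80 log units; beyond the scatter), whereas on the other core the same change gives a 1.0-fold higher number from compound 1 to compound 2 (0.01 log units; within the scatter). The effect of this change therefore did not carry from one core to the other in this pair of comparisons: the same change on two cores in this assay, a 1.0-fold higher number (0.01 log units; within the scatter) from compound 1 to compound 2 and a 6.3-fold lower number (0.80 log units; beyond the scatter) from compound 3 to compound 4, 6.5-fold (0.81 log units) apart, beyond the scatter of two such steps. Among these compounds, this shows that the core can matter for the size of the step, but with only two pairs it does not show which feature of the cores is responsible, nor how the change would behave on any further core.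

The compounds shown leave open whether chloro, methoxy or an amine at the same place would also give steps that differ between the two cores. They also leave open whether fluoro elsewhere on the phenyl ring would do so.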